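The source may hold more compounds than are shown below. What is called first, only, known or untested is meant among the compounds shown, and "the series" means these compounds.

The three measured compounds share one core and differ only in the group on the ring amine nitrogen. Compound 1 `N#Cc1ccccc1N1CCN(c2nc(=O)c3cc(C(F)(F)F)cc([N+](=O)[O-])c3s2)CC1` carries a 2-cyanophenyl there, compound 2 `CN(C(=O)CN1CCN(c2nc(=O)c3cc(C(F)(F)F)cc([N+](=O)[O-])c3s2)CC1)c1ccccc1` a (methyl(phenyl)carbamoyl)methyl and compound 3 `O=C(CN1CCN(c2nc(=O)c3cc(C(F)(F)F)cc([N+](=O)[O-])c3s2)CC1)Nc1ccccn1` a ((pyridin-2-yl)carbamoyl)methyl. In a toxicity assay on HeLa cells (Homo sapiens) for cytotoxicity, read by colorimetric assay, with a stated time of 72 h (a lower number here means that less compound is tolerated, a higher number that more compound is tolerated), compound 1 gives only a limit, > 108000 nM. In this assay compound 2 gives 70300 nM. Compound 3 gives 44500 nM in this assay, the lower of the two plain numbers, though its gap to compound 2 lies within the usual scatter. The step of an at least 2.4-fold lower number from compound 1 to compound 3 (0.38 log units; beyond the scatter) is larger, but it alters more of the molecule at once.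

Compound 4 `O=C(CN1CCN(c2nc(=O)c3cc(C(F)(F)F)cc([N+](=O)[O-])c3s2)CC1)N1CCCC1` is not yet measured and differs from compound 3 in one place: pyrrolidin-1-yl in place of (pyridin-2-yl)amino on a carbonyl carbon. The measured step that bears most on this change is the earlier swap at the same carbonyl carbon, a 1.6-fold lower number from compound 2 to compound 3 (0.20 log units; within the scatter), which stayed within the scatter. On that basis a step of no more than the scatter is expected in this assay, a 1.1-fold higher number from compound 3 to compound 4 (0.05 log units; within the scatter), in no fixed direction. Compound 4 is therefore estimated at 50000 nM, with a range from 20000 nM to 120000 nM.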

Compound 4, half-maximal cytotoxic concentration: > 106000 nM
Compound 4 gave a limit, no number; the forecaster's own chance of this, stated with the estimate: 15%; middle value at least 2.1-fold (0.32 log units) away from the limit.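

Swapping (pyridin-2-yl)amino for pyrrolidin-1-yl on the carbonyl carbon gives, in this assay, an at least 2.3-fold higher number from compound 3 to compound 4 (0.37 log units; beyond the scatter), so a change at this position can move the tolerated concentration beyond the scatter, which the earlier swap at the same carbon did not show. Measured against the methyl(phenyl)amino group of compound 2, the same pyrrolidin-1-yl group gives an at least 1.5-fold higher number from compound 2 to compound 4 (0.17 log units; that floor lies within the scatter), and that floor alone does not separate the two compounds. Compound 4 gives only a limit, and since compound 1 gives one too, the step between these two cannot be read: the limit of > 106000 nM in this assay, at which 1 of the 4 values shown sits.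

The change from compound 3 to compound 4 removes an aromatic ring and the amide hydrogen together, so the compounds shown cannot tell which of the two goes with the higher number. A cyclopentylamino group, which keeps the amide hydrogen on a non-aromatic ring, or an N-methyl-N-(pyridin-2-yl)amino group, which keeps the aromatic ring without that hydrogen, would help to pull these two features apart.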